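The source may hold more compounds than are shown below. What is called first, only, known or untested is meant among the compounds shown, and "the series" means these compounds.

Measured so far:
compound 1 `O=C(O[C@H]1C[C@H](n2cc(F)c(=O)[nH]c2=O)O[C@@H]1COP(=O)(O)Oc1ccccc1)c1ccccc1` — 1020 nM in a functional assay on Caco-2 cells (Homo sapiens) for cytotoxicity, read by MTT assay, with a stated time of 48 h; on this read-out lower numbers stand for stronger inhibition and higher numbers for weaker inhibition
compound 2 `CCCCCCCCCc1ccc(OP(=O)(O)OC[C@H]2O[C@@H](n3cc(F)c(=O)[nH]c3=O)C[C@@H]2OC(=O)c2ccccc2)cc1` — 20400 nM

For the measured compounds named here, compound 1 gives the lowest of the two numbers; its only neighbour is compound 2, reached by a 20-fold higher number from compound 1 to compound 2 (1.30 log units; beyond the scatter). The unmeasured compound 3 `O=C(O[C@H]1C[C@H](n2cc(F)c(=O)[nH]c2=O)O[C@@H]1COP(=O)(O)Oc1cccnc1)c1ccccc1` differs from compound 1 by pyridin-3-yl in place of phenyl on an oxygen. Going by the values given here, the single measured step concerns a nonyl on an aromatic carbon, not an exchange of the ring on the oxygen, so no recorded step bears directly on this change. With nothing to support a shift, the expected step is a 1.2-fold higher number from compound 1 to compound 3 (0.07 log units; within the scatter), within the scatter. Compound 3 is accordingly estimated at 1200 nM, range 450 nM to 3200 nM.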

Compound 3, half-maximal inhibitory concentration: 2500 nM
For compound 3 the middle estimate is 2.1-fold (0.32 log units) below the measured one; the range from low to high includes it.
By their numbers in this assay, from the lowest: compound 1; then compound 3; then compound 2.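

Swapping the ring on an oxygen whose other neighbours are phosphorus is not neutral in this assay: pyridin-3-yl in place of phenyl gives a 2.5-fold higher number from compound 1 to compound 3 (0.39 log units; beyond the scatter). So a change of one ring atom, with the heavy-atom count unchanged and one hydrogen-bond acceptor added, already moves the number, whereas the earlier step concerned only a nonyl on an aromatic carbon. No measurement bearing on the origin of this step is available.

Still open, on these data alone, is how pyridin-2-yl or pyridin-4-yl would compare on the same oxygen. Also open, as far as these compounds go, is whether an amine or a carboxylic acid on the phenyl ring would shift the number, and whether nonyl on the pyridin-3-yl ring would act as it does on phenyl.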